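The compounds below may be only part of what the source reports. "The series", "measured", "known", "first", "only" and "open" are said of these compounds alone.

The shared core carries a long chain on a ring nitrogen and an aromatic group on the five-membered ring. For the measured compounds named here, compound 1 `CNC(=O)CCCCCCCn1nc(-c2ccc3oc(N)nc3c2)c2c(N)ncnc21` is the only member of the set with a number: in a functional assay on CNE-2 cells (Homo sapiens) for inhibition, read by MTT assay, with a stated time of 72 h (a higher number here means a weaker inhibitor, a lower number a stronger inhibitor), compound 1 gives 2250 nM. The two hydroxycarbamoyl compounds each reach only a limit. Compound 2 `Nc1nc2cc(-c3nn(CCCC(=O)NO)c4ncnc(N)c34)ccc2o1` returns > 50000 nM in this assay, which is a limit of the assay and not a number. Compound 3 `Nc1nc2cc(-c3nn(CCCCC(=O)NO)c4ncnc(N)c34)ccc2o1` likewise returns > 50000 nM in this assay, again a limit rather than a number. The two measured steps, an at least 22-fold higher number from compound 1 to compound 2 (1.34 log units; beyond the scatter) and an at least 22-fold higher number from compound 1 to compound 3 (1.34 log units; beyond the scatter), both alter the chain end and not the aromatic group, and both end at the limit of > 50000 nM in this assay, at which 2 of the 3 values shown sit. Between compound 2 and compound 3 the two limits leave the step unreadable: a step that the two limits leave unreadable from compound 2 to compound 3.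

Compound 4 `CNC(=O)CCCCCCCn1nc(-c2cnc3[nH]ccc3c2)c2c(N)ncnc21` keeps the chain of compound 1 unchanged and alters only the aromatic group: a group of 9 heavy atoms (7 carbon, 2 nitrogen; one five-membered aromatic ring with 1 hetero atom, one six-membered aromatic ring with 1 hetero atom) in place of a group of 10 heavy atoms (7 carbon, 2 nitrogen, 1 oxygen; one five-membered aromatic ring with 2 hetero atoms, one six-membered aromatic ring of carbon only), on an aromatic carbon. Going by the values given here, no measured step touches this position, so the chain-end steps give no direct guide, and the change is set as near neutral with a wide spread. Compound 4 is therefore expected to sit close to compound 1, with a 1.3-fold higher number from compound 1 to compound 4 (0.12 log units; within the scatter) as the estimated step. The estimate for compound 4 in this assay is 3000 nM, with a range from 800 nM to 12000 nM.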

Compound 4, half-maximal inhibitory concentration: 8990 nM
Beside the measured number, compound 4's estimate is 3.0-fold (0.48 log units) below it; the measured number falls inside the stated range.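

In this assay, the aromatic group on the five-membered ring now has a readable effect of its own, since the chain is held fixed and the exchange gives a 4.0-fold higher number from compound 1 to compound 4 (0.60 log units; beyond the scatter), a modest step beyond the scatter. Replacing 2-amino-1,3-benzoxazol-5-yl with the group of 9 heavy atoms, which has no oxygen and carries its nitrogen in both rings, weakens the compound, yet compound 4 still returns a number, while compounds 2 and 3 remain the only ones at a limit of the assay: the limit of > 50000 nM in this assay, at which 2 of the 4 values shown sit. Nothing shown separates the part played by the lost oxygen and amino group from that of the changed ring pattern, and no measurement here gives a reason for the step.

This position rests on a single exchange, so a plain phenyl, a 4-aminophenyl or an indole in the same place could show whether the trend extends beyond compound 1 and compound 4. Also open, as far as these compounds go, is whether a carboxylic acid at the chain end, or a hydroxycarbamoyl group on a longer chain, would bring the series back from the limit.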